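The source may hold more compounds than are shown below. What is called first, only, known or untested is meant among the compounds shown, and "the series" means these compounds.

For the measured compounds named here, in a functional assay on CCRF-CEM cells (Homo sapiens) for inhibition, read by MTT assay, with a stated time of 72 h (a higher number here means a weaker inhibitor, a lower number a stronger inhibitor), compound 1 (`C=C(Br)C(=O)Nc1cccc(/C=C/C(=O)Nc2ccccc2)c1`) gives 190 nM and holds the lower of the two numbers so far, while compound 2 (`C=C(Br)C(=O)Nc1cccc(/C=C/C(=O)Nc2cccc3ccccc23)c1`) gives 1800 nM and the gap lies beyond the usual scatter. Compound 3 (`C=C(Br)C(=O)Nc1cccc(/C=C/C(=O)Nc2ccc(OC(F)(F)F)cc2)c1`) keeps the core of compound 1 and differs in one place: trifluoromethoxy in place of hydrogen on an aromatic carbon with trifluoromethoxy in place of hydrogen on an aromatic carbon. Going by the values given here, no measured single-place step offers guidance, so a small move toward a higher number is expected, close to the scatter. The estimated change is a 1.6-fold higher number from compound 1 to compound 3 (0.20 log units; within the scatter) in this account. For compound 3 the expected value is 300 nM with an estimated range from 90 nM to 1000 nM before measurement.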

Compound 3, half-maximal inhibitory concentration: 13000 nM
Compound 3: middle estimate off by 43-fold (1.64 log units), on the low side, and the stated range ends below it.
By their numbers in this assay, from the lowest: compound 1; then compound 2; then compound 3.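

In this assay, the only single-place step shown reveals that this aromatic carbon, para to a large group, is far from indifferent to substitution: trifluoromethoxy in place of hydrogen gives a 68-fold higher number from compound 1 to compound 3 (1.84 log units; beyond the scatter). Among the two groups compared at this position, hydrogen therefore gives the much lower number. On these data alone, it remains open whether this loss is particular to trifluoromethoxy or would also follow from a single fluorine atom, a methyl group or an amine on the same carbon. Nothing measured here accounts for the loss.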